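This account rests on a few compounds, and the source may have more. Where it says the series, first, only, none or still open, it means among the compounds named here.

Working notes on the series. Compound 1 `FC(F)(F)c1cccc(-c2nc3cnc(Nc4ccccn4)cc3[nH]2)c1` stands at the limit of the assay in a physicochemical assay for solubility, using the shake flask method, in phosphate buffer, measured as kinetic solubility, with a stated time of 20 h, at pH 6.5; a higher number here means a more soluble compound, a lower number a less soluble compound: compound 1 gives < 5000 nM, which is a limit and not a number. Compound 2 `COc1cccnc1Nc1cc2[nH]c(-c3cccc(C(F)(F)F)c3)nc2cn1` gives < 5000 nM in this assay, again a limit. Compound 3 `FC(F)(F)c1cccc(-c2nc3cnc(Nc4cnccn4)cc3[nH]2)c1` gives < 5000 nM in this assay, also a limit. Hence (the limit of < 5000 nM in this assay, at which 3 of the 3 values shown sit). The steps a step that the two limits leave unreadable from compound 1 to compound 2, a step that the two limits leave unreadable from compound 1 to compound 3 and a step that the two limits leave unreadable from compound 2 to compound 3 all sit between two limits, so none of them yields a readable size or direction.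

Compound 4 `CN1CCN(c2ccc(Nc3cc4[nH]c(-c5cccc(C(F)(F)F)c5)nc4cn3)nc2)CC1` differs from compound 1 by 4-methylpiperazin-1-yl in place of hydrogen on an aromatic carbon. Within the data shown here, no measured step in this assay makes the same change, and the three measured steps bear on it only in that all are unreadable; they give no size of step to carry over, in either direction. Compound 4 is therefore estimated in this assay at 10000 nM, with a range from 2500 nM to 60000 nM. The step of an at least 2.0-fold higher number from compound 1 to compound 4 (0.30 log units; that floor lies within the scatter) is expected to remain poorly defined, with a real chance that compound 4 again returns only a limit.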

Compound 4, solubility: 66000 nM
For compound 4 the middle estimate is 6.6-fold (0.82 log units) below the measured one; the measured number lies above the stated range.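

In this assay, among these compounds, 4-methylpiperazin-1-yl in place of hydrogen, on an aromatic carbon two atoms from the ring nitrogen and para to a large group, gives the first readable step: an at least 13-fold higher number from compound 1 to compound 4 (1.12 log units; beyond the scatter). The value of compound 1 is a limit, so the size of this step is a floor and not a measured size. Compound 4 is the only compound shown that returns a number instead of a limit: the limit of < 5000 nM in this assay, at which 3 of the 4 values shown sit.

The compounds shown leave open whether the step belongs to the ring as a whole or to its methyl, and whether morpholine, a dimethylamino group or a carboxylic acid at the same place would give a step of similar size. From the compounds shown here alone, it also remains open whether 4-methylpiperazin-1-yl would give a comparable step on compound 2 or compound 3.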